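Amide Replacement on a Naphthyl Acrylamide CDK8 Inhibitor

The source may hold more compounds than are shown below. What is called first, only, known or untested is meant among the compounds shown, and "the series" means these compounds.

Compounds measured so far:
- compound 1, `O=C(O)[C@@H]1CCCN1C(=O)/C=C/c1ccncc1-c1ccc2ccccc2c1`: "not determined" (no result reported)
- compound 2, `CNC(=O)/C=C/c1ccncc1-c1ccc2cnn(C)c2c1`: 122 nM

Compound 1 carries an acrylamide linked to a 2-carboxypyrrolidin-1-yl group on the shared core. In an assay on a protein complex for inhibition of CDK8/Cyclin C (Homo sapiens), with a stated time of 1 h (on this read-out lower numbers stand for stronger inhibition and higher numbers for weaker inhibition), compound 1 returned no result, so there is no single number for where it stands. Compound 2, which has a different aryl group and a methylamide, is the only measured reference; in this assay compound 2 gives 122 nM.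

Compound 3, `NC(=O)/C=C/c1ccncc1-c1ccc2ccccc2c1`, is the untested analogue. It differs from compound 1 in one place: amino in place of 2-carboxypyrrolidin-1-yl on a carbonyl carbon. The 2-carboxypyrrolidin-1-yl group leaves and amino enters on the carbonyl carbon. For the measured compounds named here, with no measured step between compound 1 and any other compound, the size of the change in this assay cannot be read from these data; the expectation is that compound 3 lands near the region occupied by compound 2, with no direction beyond the scatter firmly predicted. For compound 3 the estimated value in this assay is 80 nM, expected to fall between 20 nM and 400 nM.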

Compound 3, half-maximal inhibitory concentration: 10.5 nM
Beside the measured number, compound 3's estimate is 7.6-fold (0.88 log units) above it, and the stated range ends above it.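

In this assay, for the compounds shown here, compound 3 gives 10.5 nM while compound 1 has no single number, so no step between compound 1 and compound 3 can be read. The compounds shown leave open how far amino in place of 2-carboxypyrrolidin-1-yl on a carbonyl carbon shifts inhibition. Nothing shown bears on the reason for this result.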